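Tolerated dose when one methyl group moves

This account rests on a few compounds, and the source may have more. Where it says the series, first, only, none or still open, it means among the compounds named here.

Compound 1 `Cc1cc(C)cc(S(=O)(=O)n2c(=O)[nH]c3ccc(Cl)cc32)c1`: 39000 nM
Compound 2 `Cc1ccccc1S(=O)(=O)n1c(=O)[nH]c2ccc(Cl)cc21`: > 387000 nM

In an ADME assay on MT4 cells (Homo sapiens) for cytotoxicity (a lower number here means that less compound is tolerated, a higher number that more compound is tolerated), compound 2 gives > 387000 nM, which is a limit and not a number. Compound 1 gives a true reading of 39000 nM.

Compound 3 `Cc1cccc(S(=O)(=O)n2c(=O)[nH]c3ccc(Cl)cc32)c1` carries 3-methylphenyl in place of 2-methylphenyl on a sulfonyl sulfur. Within the data shown here, no measured step shows what this change does in this assay. Among the measured compounds shown here, the only numerical guide is compound 1 at 39000 nM. A downward step beyond the usual scatter is expected, with an estimated size of an at least 3.2-fold lower number from compound 2 to compound 3 (0.50 log units; beyond the scatter). For compound 3 the estimated value is 120000 nM, with an expected range of 30000 nM to 400000 nM.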

Compound 3, half-maximal cytotoxic concentration: > 307000 nM
Compound 3: only a limit was reported (the forecaster's own chance of this, stated with the estimate: 35%); middle value at least 2.5-fold (0.40 log units) from the limit.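

Hydrogen in place of methyl on an aromatic carbon gives an at least 7.8-fold higher number from compound 1 to compound 3 (0.89 log units; beyond the scatter) in this assay, so the second methyl group of compound 1 matters in this assay. The reading for compound 3, > 307000 nM, is a limit and not a number. Among these compounds, the step from compound 2 to compound 3 cannot be read, as both values are limits, so moving the single methyl group shows no measurable effect here.

Still open, as far as these compounds go, is how much compound 2 and compound 3 are actually tolerated. From the compounds shown here alone, it is also open whether an amine or a carboxylic acid on this ring would lower the number as the second methyl group does.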